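The source may report more compounds than this note shows. Statements on the series, on what has been measured and on what is new or still open speak of the compounds shown alone.

Of the compounds shown here, three have been tested in a functional assay on MCF7 cells (Homo sapiens) for cytotoxicity, read by CCK-8 assay, with a stated time of 72 h (a lower number here means a stronger inhibitor, a higher number a weaker inhibitor), so far. Compound 1 `C=CCn1c(=O)/c(=C\c2cc(Br)ccc2F)[nH]c(=O)/c1=C\c1ccccc1OC` gives 28100 nM in this assay, which is the highest number of the three, so compound 1 is the weakest inhibitor of this small set. Compound 2 `COc1ccccc1/C=c1\c(=O)[nH]/c(=C/c2cccc(Cl)c2Cl)c(=O)n1C` gives 200 nM in this assay, and compound 3 `COc1ccccc1/C=c1/[nH]c(=O)/c(=C\c2nc[nH]c2C(C)(C)C)[nH]c1=O` gives 100 nM in this assay. Both of these numbers lie far below that of compound 1, well beyond what repeated measurements usually scatter, while compound 2 and compound 3 themselves sit close enough together that nothing separates them.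

Compound 4 `C=CCn1c(=O)/c(=C\c2ccccc2F)[nH]c(=O)/c1=C\c1ccccc1OC` has not yet been measured. It differs from compound 1 in a single place: hydrogen in place of bromo on an aromatic carbon. Within the data shown here, no pair among the measured compounds differs in only one place, so no step of this kind has been observed here, and nothing in the three measured values speaks directly to what removing a bromo does on this core.

With that in mind, the expectation for compound 4 is cautious: the step of a 1.4-fold higher number from compound 1 to compound 4 (0.15 log units; within the scatter) is expected to be small, at most a modest shift toward a weaker inhibitor, and it may well fall within the usual scatter. Compound 4 is therefore expected to give about 40000 nM in this assay, with a plausible range from 12000 nM to 130000 nM.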

Compound 4, half-maximal inhibitory concentration: 23000 nM
Compound 4: the middle estimate sits 1.7-fold (0.24 log units) above what was measured; measured number inside the range.
By their numbers in this assay, from the lowest: compounds 3 and 2 (each within the scatter of the next); then compounds 4 and 1 (each within the scatter of the next).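

In this assay, swapping the bromo for hydrogen on the ring carbon gives a 1.2-fold lower number from compound 1 to compound 4 (0.09 log units; within the scatter), a step within the usual scatter, so compound 1 and compound 4 cannot be told apart. Among these compounds, this is the first direct reading of a single change in this set, and it shows that going from 5-bromo-2-fluorophenyl to 2-fluorophenyl leaves the number where it was, so the bromo at this place is not what sets the high number of compound 1 on this core. Nothing available here offers an explanation for this result.

What the compounds shown leave open is whether this place accepts any group without a shift in the number, since bromo and hydrogen are the only two seen there, and a larger or quite different group such as an amine, a carboxylic acid or a longer carbon chain might behave otherwise. As far as these compounds go, it also remains open whether the same swap would stay as small on a compound with a much lower number, or whether the fluoro group left on the ring of compound 4 matters to the number at all.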